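Removing a trifluoromethyl group: expected effect on cytotoxicity

A few compounds are considered here, and "the series" means these few. Any claim that something is new, unique, unknown or untested is made for them only; others in the source may bear on it.

The two measured compounds of this series share a nitro-bearing core carrying a polyhydroxylated phenyl ring. Compound 1 `O=[N+]([O-])C1=CNc2ncnn2C1c1ccc(O)c(O)c1` and compound 2 `O=[N+]([O-])C1=CNc2nc(C(F)(F)F)nn2C1c1ccc(O)c(O)c1O` were both tested in an ADME assay on MDCK cells (Canis lupus familiaris) for cytotoxicity; on this read-out lower numbers stand for higher toxicity in this test and higher numbers for lower toxicity in this test. In this assay compound 1 gives 368000 nM. Compound 2 gives 373000 nM, which is the higher of the two numbers, but the gap to compound 1 lies within the scatter of the test, so the two readings cannot be told apart.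

Compound 3 `O=[N+]([O-])C1=CNc2ncnn2C1c1ccc(O)c(O)c1O` has not yet been measured. The difference from compound 2 is hydrogen in place of trifluoromethyl on an aromatic carbon, so that a hydrogen stands on the aromatic carbon of the five-membered aromatic ring with three nitrogen where the trifluoromethyl sat. Within the data shown here, no step between measured compounds is available for this change. Given that compound 1, which lacks the trifluoromethyl, and compound 2, which has it, give readings within the scatter of each other, compound 3 is expected to stay essentially level with compound 2: the estimated step of a 1.0-fold lower number from compound 2 to compound 3 (0.00 log units; within the scatter) is none beyond the scatter. Compound 3 is therefore estimated at 370000 nM, with a likely range from 200000 nM to 680000 nM.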

Compound 3, half-maximal cytotoxic concentration: 405000 nM
Estimate against measurement, compound 3: 1.1-fold (0.04 log units) below, within the range that was stated.
By their numbers in this assay, from the lowest: compounds 1, 2 and 3 (each within the scatter of the next).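

Compounds 1 and 2 differed in two places at once, so neither change could be read alone, whereas compound 3 separates them. In this assay, the change at the aromatic carbon of the five-membered aromatic ring with 3 nitrogen, hydrogen in place of trifluoromethyl, gives a 1.1-fold higher number from compound 2 to compound 3 (0.04 log units; within the scatter) and so leaves the read-out indistinguishable from no change at this position. On the phenyl ring, hydroxy in place of hydrogen gives a 1.1-fold higher number from compound 1 to compound 3 (0.04 log units; within the scatter) and is likewise not resolved by the test, and no supporting measurement is available to account for either reading.

Only hydrogen and trifluoromethyl are shown at the carbon of the five-membered ring, so it remains open whether an amine or a carboxylic acid there would move the number beyond the scatter. The shared nitro group stays constant throughout, which leaves open what a nitrile in its place would do to the read-out in this assay on this core.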